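A few compounds are considered here, and "the series" means these few. Any claim that something is new, unique, unknown or untested is made for them only; others in the source may bear on it.

In a functional assay on HCT-116 cells (Homo sapiens) for inhibition, read by sulforhodamine B assay, with a stated time of 2 days (a higher number here means a weaker inhibitor of growth, a lower number a stronger inhibitor of growth), compound 1 `CC1=C(C(=O)Nc2ccc(C)cc2)C(c2ccc(O)cc2O)NC(SCc2ccccc2)=N1` gives 14500 nM. Going by the values given here, the only other measured compound, compound 2 `CC1=C(C(=O)Nc2cccc([N+](=O)[O-])c2)C(c2ccc(O)cc2O)NC(SCc2ccccc2)=N1`, gives 29000 nM, so the two values lie within the scatter of each other and compound 1 has no clear standing above or below it. The unmeasured compound 3 `CC1=C(C(=O)Nc2ccc(C)cc2)C(c2ccc(O)cc2O)NC(NCc2ccccc2)=N1` keeps the core of compound 1 and carries benzylamino in place of benzylsulfanyl on a carbon with a double bond to nitrogen, between two ring nitrogen atoms: benzylamino in place of benzylsulfanyl on a carbon with a double bond to nitrogen. Among the compounds with values here, the one measured step, a 2.0-fold higher number from compound 1 to compound 2 (0.30 log units; within the scatter), lies on an amide-type nitrogen and therefore says nothing direct about this place. Within the data shown here, no measured step touches the benzylsulfanyl group, so no step beyond the scatter is expected in this assay, though the range must stay wide. The expected step is a 1.0-fold higher number from compound 1 to compound 3 (0.01 log units; within the scatter). The estimate for compound 3 is 15000 nM, with an expected range from 5000 nM to 45000 nM.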

Compound 3, concentration for 50% growth inhibition: 66700 nM
For compound 3 the middle estimate is 4.4-fold (0.65 log units) below the measured one; measured number above the stated range.
By their numbers in this assay, from the lowest: compounds 1 and 2 (each within the scatter of the next); then compound 3.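

In this assay, going by these compounds alone, the group on the carbon with a double bond to nitrogen turns out to matter: benzylamino in place of benzylsulfanyl gives a 4.6-fold higher number from compound 1 to compound 3 (0.66 log units; beyond the scatter) and is the only step in this set that lies beyond the scatter, so this place responds more clearly than the amide-type nitrogen did. The two groups share a six-membered aromatic ring of carbon only, while benzylamino brings a hydrogen-bond donor that benzylsulfanyl lacks. The step is modest, and the exchange leaves the benzyl part intact. Nothing available explains why this exchange weakens growth inhibition.

On these data alone, it remains open whether benzyloxy, N-methyl-N-benzylamino or a longer chain such as phenethylsulfanyl would keep the number of compound 1 or move it further. Also open, as far as these compounds go, is whether the same exchange would have a similar effect with the 3-nitrophenyl amide of compound 2.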